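A few compounds are considered here, and "the series" means these few. Any claim that something is new, unique, unknown or untested is made for them only; others in the source may bear on it.

Measured so far in a functional assay on HUVEC cells (Homo sapiens) for antiproliferative activity, read by MTT assay, with a stated time of 24 h; on this read-out lower numbers stand for stronger inhibition and higher numbers for weaker inhibition:
compound 1 `C=CCOc1ccc2c(=O)c(-c3cc(OC)c(OC)cc3OC)coc2c1` gives > 10000 nM, a limit of the assay.
compound 2 `COc1cc(OC)c(-c2coc3cc(OCc4ccccc4)ccc3c2=O)cc1OC` gives 9750 nM.
compound 3 `COc1cccc(C(=O)Oc2ccc3c(=O)c(-c4cc(OC)c(OC)cc4OC)coc3c2)c1` gives > 10000 nM, a limit of the assay.

Compound 3 thus sits at the limit of > 10000 nM in this assay, at which 2 of the 3 values shown sit; in this assay only a limit is known for it. Compound 4 `COc1cc(OC)c(-c2coc3cc(OCc4ccc(Br)cc4)ccc3c2=O)cc1OC` is not yet measured and differs from compound 3 by 4-bromobenzyl in place of (3-methoxyphenyl)carbonyl on an oxygen on an aromatic ring. The step bearing on this is an at least 1.0-fold higher number from compound 2 to compound 3 (0.01 log units; that floor lies within the scatter), which the change to compound 4 largely reverses, bringing back a benzyl-type group as in compound 2; a step that the two limits leave unreadable from compound 1 to compound 3 adds nothing readable. Compound 4 is therefore expected to lie near the limit, with an at least 1.1-fold lower number from compound 3 to compound 4 (0.04 log units; that floor lies within the scatter) expected as a small downward step not clearly beyond the scatter. The estimate for compound 4 is 9000 nM, between 4000 nM and 20000 nM.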

Compound 4, half-maximal inhibitory concentration: > 10000 nM
Compound 4: only a limit was reported (the forecaster's own chance of this, stated with the estimate: 50%); middle value at least 1.1-fold (0.04 log units) from the limit.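

In this assay compound 4 gives > 10000 nM, a limit of the assay, so the 4-bromobenzyl group on this oxygen brings no readable value. Bromo in place of hydrogen on an aromatic carbon gives an at least 1.0-fold higher number from compound 2 to compound 4 (0.01 log units; that floor lies within the scatter), so no effect of the bromo can be read. The steps linking compound 1 with compound 4 and compound 3 with compound 4 cannot be read, and the series now stands here: the limit of > 10000 nM in this assay, at which 3 of the 4 values shown sit.

Going by these compounds, whether any group on this oxygen gives a value clearly under that limit stays open. An amine or a carboxylic acid on a longer chain there remains untested among the compounds shown.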